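The source may report more compounds than this note shows. Statements on the series, on what has been measured and on what is new or still open speak of the compounds shown alone.

Working notes on the series. In a functional assay on HCT-116 cells (Homo sapiens) for cytotoxicity, read by sulforhodamine B assay, with a stated time of 48 h (on this read-out higher numbers stand for weaker inhibition and lower numbers for stronger inhibition), compound 1 (`COc1cc(/C=C/C(=O)/C=C/c2cccs2)ccc1OCc1cn(CCOc2cc(=O)oc3ccccc23)nn1`) gives 9290 nM, compound 2 (`COc1cc(/C=C/C(=O)/C=C/c2cc(OC)c(OC)c(OC)c2)ccc1OCc1cn(CCOc2cc(=O)oc3ccccc23)nn1`) gives 2210 nM and compound 3 (`COc1cc(/C=C/C(=O)/C=C/c2ccco2)ccc1OCc1cn(CCOc2cc(=O)oc3ccccc23)nn1`) gives 9180 nM. Compound 3 therefore lies within the scatter of compound 1 and well above compound 2 on the numbers shown.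

Compound 4 (`COc1ccccc1/C=C/C(=O)/C=C/c1ccc(OCc2cn(CCOc3cc(=O)oc4ccccc34)nn2)c(OC)c1`) differs from compound 3 in one group: 2-methoxyphenyl in place of furan-2-yl on a double-bonded chain carbon bound to a double-bonded chain carbon. In words, 2-methoxyphenyl stands in place of furan-2-yl on a double-bonded chain carbon bound to a double-bonded chain carbon.

Three measured steps at this same place bear on the change. The exchange of the two five-membered rings is flat, with a 1.0-fold lower number from compound 1 to compound 3 (0.01 log units; within the scatter). The 3,4,5-trimethoxyphenyl group gives the only clear shift, with a 4.2-fold lower number from compound 1 to compound 2 (0.62 log units; beyond the scatter) and a 4.2-fold higher number from compound 2 to compound 3 (0.62 log units; beyond the scatter). The 2-methoxyphenyl group has not been measured, so only part of that shift is expected to carry over.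

The expected move in this assay is small and toward a lower number, a 1.8-fold lower number from compound 3 to compound 4 (0.26 log units; within the scatter). For compound 4 the estimated value is 5000 nM, with an expected range of 2000 nM to 11000 nM.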

Compound 4, half-maximal inhibitory concentration: 9490 nM
Compound 4: the middle estimate sits 1.9-fold (0.28 log units) below what was measured; low and high end bracket the measured number.
By their numbers in this assay, from the lowest: compound 2; then compounds 3, 1 and 4 (each within the scatter of the next).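

In this assay, the 2-methoxyphenyl group falls level with both five-membered rings, with a 1.0-fold higher number from compound 3 to compound 4 (0.01 log units; within the scatter) and a 1.0-fold higher number from compound 1 to compound 4 (0.01 log units; within the scatter), so going from 5 to 8 heavy atoms at this place, and from a five-membered aromatic ring to a six-membered one of carbon only, moves nothing on its own. The shift seen with 3,4,5-trimethoxyphenyl does not carry over to this single-methoxy group, with a 4.3-fold higher number from compound 2 to compound 4 (0.63 log units; beyond the scatter), which leaves compound 2 alone among the four in giving a lower number. No measured evidence on offer accounts for this difference.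

On these data alone, it remains open whether a dimethoxyphenyl group at this place would side with compound 2 or with compound 4. Also open, as far as these compounds go, is how an unsubstituted phenyl or an aminophenyl group would read here.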